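From butyl to benzyl: one measured number so far

A few compounds are considered here, and "the series" means these few. Any claim that something is new, unique, unknown or untested is made for them only; others in the source may bear on it.

Of the compounds shown here, three have been tested in a functional assay for inhibition, with Rattus norvegicus as the target, at pH 7.35; on this read-out higher numbers stand for weaker inhibition and lower numbers for stronger inhibition. Compound 1 `CCOC(=O)C(=O)C(CC)NC(=O)C(CC(C)C)NC(=O)C(c1ccccc1)c1ccccc1` gives only a limit, > 100000 nM. Compound 2 `CCOC(=O)C(=O)C(CC)NC(=O)C(CC(C)C)NC(=O)OCC(C)C` also gives only a limit, > 300000 nM. Within the data shown here, compound 3 `CCCCNC(=O)C(=O)C(CC)NC(=O)C(CC(C)C)NC(=O)OCc1ccccc1` is the only one with a true number, 35000 nM. Compound 4 `CCC(NC(=O)C(CC(C)C)NC(=O)OCc1ccccc1)C(=O)C(=O)NCc1ccccc1` differs from compound 3 in one place: phenyl in place of propyl on a saturated chain carbon bound to an amide-type nitrogen, turning butylcarbamoyl into benzylcarbamoyl. Among the measured compounds shown here, no measured pair shows what such a swap does, so the only anchor is compound 3 at 35000 nM, and no change beyond the usual scatter is expected in this assay. The expected step of a 1.2-fold lower number from compound 3 to compound 4 (0.07 log units; within the scatter) is small. Compound 4 is estimated at 30000 nM, with an expected range of 8000 nM to 100000 nM.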

Compound 4, half-maximal inhibitory concentration: 50000 nM
The estimate for compound 4 lay 1.7-fold (0.22 log units) below the measured number; low and high end bracket the measured number.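

In this assay, among these compounds, the step of a 1.4-fold higher number from compound 3 to compound 4 (0.15 log units; within the scatter) gives a second true number for this series and the first measured swap at this position. Phenyl in place of propyl here, turning butylcarbamoyl into benzylcarbamoyl, adds a six-membered aromatic ring, yet the two numbers cannot be told apart. Nothing at hand bears on why this swap leaves the number within the scatter. Still open, on these data alone, is whether a longer chain, an amine or a carboxylic acid at this place would move the number beyond the scatter.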